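Chain-end variation in a leukotriene receptor series

A few compounds are considered here, and "the series" means these few. Any claim that something is new, unique, unknown or untested is made for them only; others in the source may bear on it.

Measured so far:
compound 1 `CCc1cc(C(C)=O)c(O)cc1OCCCC(C)(C)C#N`: 85%
compound 2 `CCc1cc(C(C)=O)c(O)cc1OCCCC(C)(C)C(N)=O`: 92%
compound 3 `CCc1cc(C(C)=O)c(O)cc1OCCCCCC(C)(C)c1nnnn1C`: 99%

All three were run in an assay on isolated protein for inhibition of leukotriene B4 receptor 1 (Homo sapiens), tested at 10 uM; on this read-out higher numbers stand for more inhibition at the one concentration tested (going by the name of the read-out) and lower numbers for less inhibition. Compound 3 holds the highest of the three numbers. Against compound 2 the gap is within the scatter, so the two cannot be ordered; against compound 1 the gap is beyond the scatter, so compound 3 does read higher than compound 1. Going by the values given here, the only step between measured compounds that differ in one place is a number 7 percentage points higher from compound 1 to compound 2 (within the scatter).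

Compound 4 `CCc1cc(C(C)=O)c(O)cc1OCCCCCCSC` is not yet measured. Its change from compound 3 is (methylsulfanyl)methyl in place of 1-methyl-1-(1-methyl-1H-tetrazol-5-yl)ethyl on a saturated chain carbon, five bonds along the chain from an oxygen on an aromatic ring. Among the compounds with values here, no measured step touches this position or either of these groups; the step from compound 1 to compound 2 concerns a different chain carbon and different groups, and it was small in any case. It gives no direct guide here.

Compound 3 sits near the top of the percentage scale, so an upward move cannot be large. Given that a sizeable part of the chain end is removed, a drop beyond the scatter is expected, of the order a number 21 percentage points lower from compound 3 to compound 4 (beyond the scatter). For compound 4 the estimate in this assay is 78%, with a range from 55% to 95%.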

Compound 4, a percentage reported as inhibition, at one concentration (the size of the read-out at that concentration, not a potency): 71%
Beside the measured number, compound 4's estimate is 7 percentage points above it; low and high end bracket the measured number.
By their numbers in this assay, from the lowest: compound 4; then compounds 1, 2 and 3 (each within the scatter of the next, the first and the last beyond it).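

In this assay the chain end proves able to move the reading beyond the scatter, which the earlier step did not show: the change gives a number 28 percentage points lower from compound 3 to compound 4 (beyond the scatter) with (methylsulfanyl)methyl in place of 1-methyl-1-(1-methyl-1H-tetrazol-5-yl)ethyl on a saturated chain carbon, five bonds along the chain from an oxygen on an aromatic ring. Measured against the other two compounds, 3-(methylsulfanyl)propyl on a saturated chain carbon, three bonds along the chain from an oxygen on an aromatic ring, gives a number 21 percentage points lower from compound 2 to compound 4 (beyond the scatter) in place of 1-carbamoyl-1-methylethyl and a number 14 percentage points lower from compound 1 to compound 4 (beyond the scatter) in place of 1-cyano-1-methylethyl, so all three chain ends carrying the 1-methylethyl unit read higher than the thioether, with no compound shown going against this. No measurement on hand accounts for these drops.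

Each of these steps exchanges a whole chain end, so the compounds shown do not separate the effect of losing the tetrazole, the amide or the nitrile from that of gaining the sulfur. As far as these compounds go, a simple tert-butyl end or a carboxylic acid on the same chain remains open, as does whether chain length alone changes the reading.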